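The source may hold more compounds than are shown below. What is called first, only, known or untested is meant among the compounds shown, and "the series" means these compounds.

In an ADME assay on L02 cells (Homo sapiens) for cytotoxicity, read by MTT assay, with a stated time of 48 h (on this read-out higher numbers stand for weaker inhibition and lower numbers for stronger inhibition), the three measured compounds stand as follows.
Compound 1, `COC(=O)CC1CCN(C[C@H]2CN(c3ccc(-n4cc(-c5ccccn5)cn4)c(F)c3)C(=O)O2)CC1`, gives > 400 ug/mL, a limit of the assay.
Compound 2, `O=C1CCC(=O)N1C[C@H]1CN(c2ccc(-n3cc(-c4ccccn4)cn3)c(F)c2)C(=O)O1`, gives > 400 ug/mL, likewise a limit of the assay.
Compound 3, `CCC(=O)NC[C@H]1CN(c2ccc(-n3cc(-c4ccccn4)cn3)c(F)c2)C(=O)O1`, gives 204 ug/mL.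

Compound 2 thus sits at the limit of > 400 ug/mL in this assay, at which 2 of the 3 values shown sit, and only a limit is known for it. The unmeasured compound 4 is `CS(=O)(=O)NC[C@H]1CN(c2ccc(-n3cc(-c4ccccn4)cn3)c(F)c2)C(=O)O1`; its difference from compound 2 is methanesulfonamido in place of 2,5-dioxopyrrolidin-1-yl on a saturated chain carbon bound to a saturated ring carbon. Among the measured compounds shown here, the only measured step that starts from compound 2 is an at least 1.9-fold lower number from compound 2 to compound 3 (0.29 log units; that floor lies within the scatter), and the parallel step an at least 1.9-fold lower number from compound 1 to compound 3 (0.29 log units; that floor lies within the scatter) reads the same way, each with a floor inside the scatter. The step that the two limits leave unreadable from compound 1 to compound 2 remains unreadable. On this footing no step beyond the scatter is expected, and compound 4 is expected to stay close to the limit, a change of an at least 1.3-fold lower number from compound 2 to compound 4 (0.12 log units; that floor lies within the scatter). Compound 4 is therefore estimated at 300 ug/mL, between 150 ug/mL and 600 ug/mL.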

Compound 4, half-maximal inhibitory concentration: > 400 ug/mL
Compound 4 gave a limit, no number; the forecaster's own chance of this, stated with the estimate: 50%; middle value at least 1.3-fold (0.12 log units) from the limit.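

In this assay compound 4 ends at a limit of the assay, not at a number, so methanesulfonamido joins the two groups already at that limit on this saturated chain carbon: the limit of > 400 ug/mL in this assay, at which 3 of the 4 values shown sit. Compound 4 carries a hydrogen-bond donor that compound 2 lacks, yet both end at the limit, and the steps to compound 4 from compound 1 and compound 2 cannot be read. Methylsulfonyl in place of propanoyl on the amine nitrogen gives an at least 1.9-fold higher number from compound 3 to compound 4 (0.29 log units; that floor lies within the scatter), a floor that stays within the scatter.

Among the compounds shown here, compound 3 therefore remains the only compound with a number. As far as these compounds go, whether an amine, a carboxylic acid or a longer acyl chain at this place would also give a number stays open.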